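This account rests on a few compounds, and the source may have more. Where it says the series, first, only, none or still open, it means among the compounds named here.

Measured in an ADME assay on J774.A1 cells (Mus musculus) for cytotoxicity, read by MTT assay, with a stated time of 48 h; on this read-out higher numbers stand for lower toxicity in this test and lower numbers for higher toxicity in this test:
- compound 1 `C/C(=C\c1ccccc1)C(=O)/C=C/c1ccccc1`: 34500 nM
- compound 2 `C/C(=C\c1ccccc1)C(=O)/C=C/c1ccc([N+](=O)[O-])cc1`: 26000 nM

For the measured compounds named here, compound 2 stands at 26000 nM, within the scatter of compound 1, so the two numbers give no order between these compounds. The next compound to be tested is compound 3 `C/C(=C\c1ccc(N(C)C)cc1)C(=O)/C=C/c1ccc([N+](=O)[O-])cc1`. It differs from compound 2 by dimethylamino in place of hydrogen on an aromatic carbon, on a six-membered aromatic ring of carbon only, para to a large group.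

Going by the values given here, only one measured step bears on this change: a 1.3-fold lower number from compound 1 to compound 2 (0.12 log units; within the scatter), for nitro in place of hydrogen on an aromatic carbon. Among the compounds with values here, that step stayed within the scatter, but it involves a different group, and no measured step introduces dimethylamino. It therefore offers weak guidance, and the data give no firm direction for the new change. In this assay, no shift beyond the scatter is expected, and the expected step is a 1.2-fold lower number from compound 2 to compound 3 (0.07 log units; within the scatter). The estimate for compound 3 is 22000 nM, with an expected range from 7000 nM to 60000 nM.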

Compound 3, half-maximal cytotoxic concentration: 967000 nM
For compound 3 the middle estimate is 44-fold (1.64 log units) below the measured one; the measured number lies above the stated range.
By their numbers in this assay, from the lowest: compounds 2 and 1 (each within the scatter of the next); then compound 3.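

In this assay, for the compounds shown here, dimethylamino in place of hydrogen on an aromatic carbon, para to a large group, gives a 37-fold higher number from compound 2 to compound 3 (1.57 log units; beyond the scatter), the only step so far that lies beyond the scatter, and it runs towards lower toxicity in this test. The earlier change, with a 1.3-fold lower number from compound 1 to compound 2 (0.12 log units; within the scatter), stayed within the scatter, so compounds 1 and 2 gave no sign that a single substitution on the shared core could move this read-out so far. No measurement at hand bears on what lies behind the size of this step.

The compounds shown leave open whether the step belongs to dimethylamino in particular, or would also come with a primary amine, a methoxy group or a longer dialkylamino chain at this place. They also leave open whether the nitro group shared by compound 2 and compound 3 has any part in the size of the step.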